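Working notes: amino on the ring nitrogen of compound 1

The source may report more compounds than this note shows. Statements on the series, on what has been measured and on what is new or still open speak of the compounds shown alone.

Compound 1 `Cc1ccc(-c2nc3ccc(Cl)cc3c(=O)[nH]2)cc1` gives 9.86 ug/mL in a functional assay on HepG2 cells (Homo sapiens) for antiproliferative activity, read by MTT assay, with a stated time of 48 h; on this read-out higher numbers stand for weaker inhibition and lower numbers for stronger inhibition.
Compound 2 `Cc1ccc(-c2nc(N)c3cc(Cl)ccc3n2)cc1` gives 14.5 ug/mL in this assay.

Compound 1 has the lowest of the two numbers, yet compound 2 sits within the scatter of it, so the two are not separated. Compound 3 `Cc1ccc(-c2nc3ccc(Cl)cc3c(=O)n2N)cc1` differs from compound 1 by amino in place of hydrogen on an aromatic nitrogen, in words amino in place of hydrogen on an aromatic nitrogen. Among the measured compounds shown here, no step between measured compounds matches this change, so nothing measured points either way. In this assay the expectation is no shift beyond the scatter, with the step from a 1.1-fold higher number from compound 1 to compound 3 (0.05 log units; within the scatter) kept small. Compound 3 is therefore estimated at 11 ug/mL, within 4.5 ug/mL to 28 ug/mL.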

Compound 3, half-maximal inhibitory concentration: 18.4 ug/mL
Compound 3: the middle estimate sits 1.7-fold (0.22 log units) below what was measured; the measured number falls inside the stated range.
By their numbers in this assay, from the lowest: compounds 1, 2 and 3 (each within the scatter of the next).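

In this assay, amino in place of hydrogen on an aromatic nitrogen gives a 1.9-fold higher number from compound 1 to compound 3 (0.27 log units; within the scatter). Among the compounds shown here, this is the first reading at this position, and it shows that the ring nitrogen can carry amino instead of hydrogen with the number staying within the scatter of compound 1. No measurement bearing on this step is available to account for it.

From the compounds shown here alone, whether a larger group on this nitrogen, such as a methyl group or a longer chain, also stays within the scatter remains open. Going by these compounds, a carboxylic acid at this position is equally open.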